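The compounds below may be only part of what the source reports. "The series", "measured", "known", "first", "only" and "open" are said of these compounds alone.

Measured so far in a functional assay on UO-31 cells (Homo sapiens) for inhibition, read by sulforhodamine B assay, with a stated time of 48 h, tested at 10 uM; on this read-out lower numbers stand for less inhibition and higher numbers for more inhibition at the one concentration tested (going by the name of the read-out):
compound 1 `COc1ccc(-c2cn3ccnc3c(-c3ccc4ncn(C5CCCCC5)c4c3)n2)cc1`, giving 61.5%
compound 2 `Brc1ccc(-c2cn3ccnc3c(-c3ccc4ncn(C5CCCCC5)c4c3)n2)cc1`, giving 42.9%

Going by the values given here, compound 2 stands lowest of the two numbers; the one change measured is a number 18.6 percentage points lower from compound 1 to compound 2 (beyond the scatter). Compound 3 `Fc1ccccc1-c1cn2ccnc2c(-c2ccc3ncn(C4CCCCC4)c3c2)n1` differs from compound 2 by 2-fluorophenyl in place of 4-bromophenyl on an aromatic carbon. Among the compounds with values here, no measured step covers this exchange of one ring substituent for another at a different position on the same ring; the only comparison available, from compound 1 to compound 2, was modest. In this assay a step of modest size at most, with no clear direction, is therefore expected, a number 5.1 percentage points higher from compound 2 to compound 3 (within the scatter). Compound 3 is estimated at 48%, between 28% and 68%.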

Compound 3, a percentage reported as inhibition, at one concentration (the size of the read-out at that concentration, not a potency): 22.9%
Estimate against measurement, compound 3: 25.1 percentage points above, and the stated range ends above it.
By their numbers in this assay, from the lowest: compound 3; then compound 2; then compound 1.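

In this assay the aryl group on the shared core proves sensitive to more than one exchange: 2-fluorophenyl in place of 4-bromophenyl gives a number 20 percentage points lower from compound 2 to compound 3 (beyond the scatter), and 2-fluorophenyl in place of 4-methoxyphenyl gives a number 38.6 percentage points lower from compound 1 to compound 3 (beyond the scatter). Compound 3 therefore stands lowest of the three, with both of its steps beyond the scatter. No evidence at hand explains these drops. In compound 3 the halogen and its place on the ring change together, so their separate contributions cannot be told apart. Going by these compounds, how an amine or a carboxylic acid on this ring would read also stays open.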